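The source may hold more compounds than are shown below. What is called first, only, known or untested is meant among the compounds shown, and "the series" means these compounds.

Measured compounds:
compound 1 `COc1nc(N)nc2c1c(-c1cc3ccccc3o1)cn2[C@@H]1O[C@H](CO)[C@@H](O)[C@H]1O`, 25600 nM
compound 2 `Nc1nc(N)c2c(-c3cc4ccccc4o3)cn([C@@H]3O[C@H](CO)[C@@H](O)[C@H]3O)c2n1`, > 100000 nM
compound 3 `COc1ncnc2c1c(-c1cccs1)cn2[C@@H]1O[C@H](CO)[C@@H](O)[C@H]1O`, 62800 nM

In an ADME assay on BJ cells (Homo sapiens), read by MTT assay, with a stated time of 72 h (a higher number here means a weaker inhibitor, a lower number a stronger inhibitor), compound 1 gives 25600 nM, the lowest of the two numbers at hand. Compound 3 gives 62800 nM in this assay, and it differs from compound 1 in two places, so the gap between them cannot be assigned to a single change. The value of compound 2 in this assay, > 100000 nM, is a limit of the assay and not a number (the limit of > 100000 nM in this assay, at which 1 of the 3 values shown sits). Among the compounds with values here, the one single-place step that was measured, an at least 3.9-fold higher number from compound 1 to compound 2 (0.59 log units; beyond the scatter), concerns the amino in place of methoxy on an aromatic carbon and thus a different part of the core than the step under consideration.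

Compound 4 `COc1nc(N)nc2c1c(-c1ccccc1)cn2[C@@H]1O[C@H](CO)[C@@H](O)[C@H]1O` differs from compound 1 as follows: phenyl in place of 1-benzofuran-2-yl on an aromatic carbon. Within the data shown here, no measured step addresses this exchange, so nothing in the data points to a direction beyond the scatter for it. Compound 4 is therefore expected to lie near compound 1 in this assay, with a wide range to reflect the missing precedent, and its estimate is 40000 nM (from 12000 nM to 100000 nM). The step this estimate implies is a 1.6-fold higher number from compound 1 to compound 4 (0.19 log units; within the scatter), an expected change that stays close to the scatter.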

Compound 4, half-maximal inhibitory concentration: > 100000 nM
Compound 4: only a limit was reported; the forecaster's own chance of this, stated with the estimate: 30%; middle value at least 2.5-fold (0.39 log units) away from the limit.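

Within the data shown here, the exchange of 1-benzofuran-2-yl for phenyl on this aromatic carbon, two ring bonds from the ring nitrogen, is the first single-place step measured at this position, and in this assay it gives an at least 3.9-fold higher number from compound 1 to compound 4 (0.59 log units; beyond the scatter). The value of compound 4, > 100000 nM, is a limit of the assay and not a number, so the step shows a direction and a smallest size but no full size. The group at this position therefore matters for the reading of compound 1 in this assay, and each of the two single-place changes from compound 1 shown here ends at the same limit: the limit of > 100000 nM in this assay, at which 2 of the 4 values shown sit.

The compounds shown leave open whether the reading of compound 1 depends on the fused second ring or on the ring oxygen of 1-benzofuran-2-yl, which a furan-2-yl or a naphthalen-2-yl group on the same carbon could separate. They also leave open how a phenyl group carrying an amine or a carboxylic acid would read on the core of compound 1, and whether such a group would come back below the limit.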